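Tosylate replacement of benzylamino on the bromo core

The compounds below may be only part of what the source reports. "The series", "measured", "known", "first", "only" and "open" are said of these compounds alone.

Measured so far:
- compound 1, `O=C(NCc1ccc(F)cc1)c1nc(Br)c2cccnc2c1NCCCNc1c(C(=O)NCc2ccc(F)cc2)nc(Br)c2cccnc12`, in a toxicity assay on C8166 cells (Homo sapiens) for cytotoxicity, read by MTT assay, with a stated time of 72 h (a lower number here means that less compound is tolerated, a higher number that more compound is tolerated), recorded as "not determined" (no result reported)
- compound 2, `O=C(NCc1ccc(F)cc1)c1nc(Br)c2cccnc2c1NCc1ccccc1`, in this assay recorded as "not determined" (no result reported)
- compound 3, `O=C(NCc1ccc(F)cc1)c1nc(NCCO)c2cccnc2c1O`, this assay 91000 nM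

Compound 2 stands without a number: this assay reports "not determined" (no result reported) for it, and compound 1 likewise stands at "not determined" (no result reported) in this assay. Among the compounds with values here, the only value at hand is that of compound 3, which gives 91000 nM in this assay, so compound 2 cannot be placed against any neighbour, and no step from a measured pair exists to scale the change to compound 4, `Cc1ccc(S(=O)(=O)Oc2c(C(=O)NCc3ccc(F)cc3)nc(Br)c3cccnc23)cc1`.

The change from compound 2 to compound 4 is ((4-methylphenyl)sulfonyl)oxy in place of benzylamino on an aromatic carbon.

Within the data shown here, with no measured pair sharing this change, the size of the step in this assay cannot be read from the data; the expectation is no more than a modest shift, in either direction, not clearly beyond the usual scatter. Among the measured compounds shown here, compound 4 is expected to give about 45000 nM in this assay, within a range of 12000 nM to 160000 nM, resting only on the single value of compound 3 as the series anchor.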

Compound 4, half-maximal cytotoxic concentration: 31000 nM
For compound 4 the middle estimate is 1.5-fold (0.16 log units) above the measured one; measured number inside the range.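

No new step can be read, since compound 2 stands at "not determined" (no result reported) in this assay while compound 4 gives 31000 nM. The compounds shown leave open how ((4-methylphenyl)sulfonyl)oxy in place of benzylamino shifts this read-out on the shared core. No supporting data bear on this result.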